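Swapping the aryl group on the piperazine ring

The source may report more compounds than this note shows. Statements on the series, on what has been measured and on what is new or still open speak of the compounds shown alone.

Compound 1 `CCCc1nc(-c2ccccc2)c(CNCCN2CCN(c3ccc(Cl)cc3)CC2)o1` — 55.8%
Compound 2 `CCCc1nc(-c2ccccc2)c(CNCCCN2CCN(c3cccc(OC)c3)CC2)o1` — 36.4%

Both compounds were tested in an assay on HEK293 cells for inhibition of Voltage-dependent T-type calcium channel subunit alpha-1G (Homo sapiens), read by fluorescence, tested at 10 uM; a lower number here means less inhibition, a higher number more inhibition at the concentration tested (going by the name of the read-out). Compound 1 gives 55.8% and compound 2 gives 36.4%; compound 2 thus stands lowest of the two numbers, and the gap to compound 1 is larger than the usual scatter of this kind of measurement. The two differ in more than one place, so the values alone cannot be pinned on a single change.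

Compound 3 `CCCc1nc(-c2ccccc2)c(CNCCCN2CCN(c3ccccc3C(F)(F)F)CC2)o1` has not yet been measured. It differs from compound 2 in one place: 2-(trifluoromethyl)phenyl in place of 3-methoxyphenyl on an amine nitrogen in a ring. Within the data shown here, no measured pair shows the effect of this kind of change, so the size of the step is uncertain; a small rise or no change beyond the scatter seems most likely. The expected step from compound 2 to compound 3 is a number 8.6 percentage points higher from compound 2 to compound 3 (within the scatter). Compound 3 is estimated at 45%, with a range from 20% to 70%.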

Compound 3, a percentage reported as inhibition, at one concentration (the size of the read-out at that concentration, not a potency): 45%
Compound 3: middle estimate and measured number agree at the digits printed; the measured number falls inside the stated range.
By their numbers in this assay, from the lowest: compounds 2 and 3 (each within the scatter of the next); then compound 1.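

In this assay, the exchange of 3-methoxyphenyl for 2-(trifluoromethyl)phenyl on the ring nitrogen gives a number 8.6 percentage points higher from compound 2 to compound 3 (within the scatter). Among these compounds, this is the first comparison here that changes one place only, and it shows that this nitrogen can carry either aryl group without a difference beyond the scatter, even though the entering group has 10 heavy atoms rather than 8 and no hydrogen-bond acceptor rather than 1. No measurement shown here accounts for this result.

Compound 1 differs from compound 2 and from compound 3 in more than one place, so those steps cannot be read, and the separate contributions of its aryl group and its linking chain stay unresolved. Also open, going by these compounds, is how an unsubstituted phenyl or a pyridine ring on this nitrogen would compare.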